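Methylation of a Phenol in a Urea Series

A few compounds are considered here, and "the series" means these few. Any claim that something is new, unique, unknown or untested is made for them only; others in the source may bear on it.

Compound 2 `O=C(Nc1cccc(-n2cc(-c3ccncc3)c(-c3cc(O)cc(Cl)c3)n2)c1)Nc1ccc(Cl)c(C(F)(F)F)c1`: 15.1%
Compound 1 `COc1cc(Cl)cc(-c2nn(-c3cccc(NC(=O)c4ccc(Cl)c(Cl)c4)c3)cc2-c2ccncc2)c1`: 62.3%

In a functional assay on KM12 cells (Homo sapiens) for inhibition, read by sulforhodamine B assay, with a stated time of 48 h, tested at 10 uM (on this read-out lower numbers stand for a stronger effect and higher numbers for a weaker effect at the one concentration tested), compound 2 gives 15.1%, the lowest of the two numbers shown, and compound 1 gives 62.3%, a gap beyond the scatter. Compound 3 `COc1cc(Cl)cc(-c2nn(-c3cccc(NC(=O)Nc4ccc(Cl)c(C(F)(F)F)c4)c3)cc2-c2ccncc2)c1` is the unmeasured partner of compound 2; it differs in one place: methyl in place of hydrogen on an oxygen on an aromatic ring. Among the measured compounds shown here, with no measured pair showing this change alone, the expectation for it is a step of a number 16.9 percentage points higher from compound 2 to compound 3 (beyond the scatter) toward weaker effect, of a size only modestly beyond the scatter. Compound 3 is therefore expected to give 32%, within a range from 10% to 65%.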

Compound 3, a percentage reported as activity, at one concentration (the size of the read-out at that concentration, not a potency): 9.1%
For compound 3 the middle estimate is 22.9 percentage points above the measured one; measured number below the stated range.
By their numbers in this assay, from the lowest: compounds 3 and 2 (each within the scatter of the next); then compound 1.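

In this assay, methyl in place of hydrogen on this oxygen gives a number 6 percentage points lower from compound 2 to compound 3 (within the scatter), so in the urea series the read-out does not separate hydroxy from methoxy at this position. With the methoxy held fixed, (4-chloro-3-(trifluoromethyl)phenyl)amino in place of 3,4-dichlorophenyl on the carbonyl carbon gives a number 53.2 percentage points lower from compound 1 to compound 3 (beyond the scatter), which places a large step at that change rather than at this oxygen. Nothing on hand explains either step.

The compounds shown leave open whether an ethoxy group or a longer chain on this oxygen, or an amine in place of the hydroxy, would give a similar read-out.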